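Swapping the Sulfonyl Aryl Group: From Compound 2 to 3

The source may report more compounds than this note shows. Statements on the series, on what has been measured and on what is new or still open speak of the compounds shown alone.

Two compounds have been measured so far in a functional assay on LNCaP cells (Homo sapiens) for antiproliferative activity, read by fluorescence and propidium iodide staining, with a stated time of 96 h; on this read-out higher numbers stand for weaker inhibition and lower numbers for stronger inhibition:

Compound 1, `CC(O)(CS(=O)(=O)c1cccc(C(F)(F)F)c1)C(=O)Nc1cc(C(F)(F)F)cc(C(F)(F)F)c1`: compound 1 gives 9500 nM
Compound 2, `CC(O)(CS(=O)(=O)c1ccccc1C(F)(F)F)C(=O)Nc1cc(C(F)(F)F)cc(C(F)(F)F)c1`: compound 2 gives 8510 nM

Compound 2 holds the lower of these two numbers, yet the step of a 1.1-fold lower number from compound 1 to compound 2 (0.05 log units; within the scatter) lies within the scatter, so on this read-out the two compounds cannot be told apart. Compound 3, `CC(O)(CS(=O)(=O)c1cccc(OC(F)(F)F)c1)C(=O)Nc1cc(C(F)(F)F)cc(C(F)(F)F)c1`, has not yet been measured. It differs from compound 2 in one place: 3-(trifluoromethoxy)phenyl in place of 2-(trifluoromethyl)phenyl on a sulfonyl sulfur. Among the measured compounds shown here, only one measured step touches the same position on the sulfonyl sulfur, and that step was a 1.1-fold lower number from compound 1 to compound 2 (0.05 log units; within the scatter), too small to count. For the measured compounds named here, nothing measured here shows what a trifluoromethoxy group on that ring does, so the only guide is that the one change tried at this position left the number essentially where it was. The expectation for compound 3 is therefore a number close to that of compound 2, a step of a 1.1-fold higher number from compound 2 to compound 3 (0.02 log units; within the scatter), with no shift beyond the scatter. The estimate for compound 3 is 9000 nM, in a range from 4000 nM to 20000 nM.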

Compound 3, half-maximal inhibitory concentration: 9340 nM
Estimate against measurement, compound 3: 1.0-fold (0.02 log units) below; measured number inside the range.
By their numbers in this assay, from the lowest: compounds 2, 3 and 1 (each within the scatter of the next).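

With the third compound, the group on the sulfonyl sulfur has now been varied in two ways, and neither can be told apart from the others in this assay. Trifluoromethoxy in place of trifluoromethyl on an aromatic carbon, a direct swap of one fluorinated group for another, gives a 1.0-fold lower number from compound 1 to compound 3 (0.01 log units; within the scatter), while 3-(trifluoromethoxy)phenyl in place of 2-(trifluoromethyl)phenyl, which brings in an oxygen and a hydrogen-bond acceptor that the leaving group does not have, gives a 1.1-fold higher number from compound 2 to compound 3 (0.04 log units; within the scatter), so all three aryl groups shown sit within the scatter of one another. Nothing measured here offers a reason for this sameness.

As far as these compounds go, all three compounds carry a fluorinated group on that ring, so it remains open what a plain phenyl, a ring bearing an amine or a carboxylic acid, or a simple methyl group on the sulfonyl sulfur would give. The three also share the rest of the core, including its hydroxyl group and its bis(trifluoromethyl)phenyl amide, and they say nothing about how the number responds when those parts change.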